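A 3-Chlorobenzyl Group in Place of 2-Fluorobenzyl

This account rests on a few compounds, and the source may have more. Where it says the series, first, only, none or still open, it means among the compounds named here.

Of the compounds shown here, two have been measured so far in a functional assay on MCF7 cells (Homo sapiens) for cytotoxicity, read by MTT assay, with a stated time of 24 h; on this read-out higher numbers stand for weaker inhibition and lower numbers for stronger inhibition. Compound 1 (`COc1ccc(/C=C2\CN(C(=S)SCc3cn(Cc4ccccc4F)nn3)C/C(=C\c3ccc(OC)cc3)C2=O)cc1`) gives 79400 nM. Compound 2 (`O=C1/C(=C/c2ccccc2F)CN(Cc2cn(Cc3ccccc3F)nn2)C/C1=C\c1ccccc1F`) gives 6000 nM, the lower of the two numbers, and its gap to compound 1 lies beyond the usual scatter.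

Compound 3 (`O=C1/C(=C/c2ccccc2F)CN(Cc2cn(Cc3cccc(Cl)c3)nn2)C/C1=C\c1ccccc1F`) has not yet been measured. It departs from compound 2 in one place: 3-chlorophenyl in place of 2-fluorophenyl on a saturated chain carbon bound to an aromatic nitrogen. This places 3-chlorophenyl in place of 2-fluorophenyl on a saturated chain carbon bound to an aromatic nitrogen, a change that also reads as 2-fluorobenzyl to 3-chlorobenzyl.

For the measured compounds named here, no measured pair of compounds differs in only one place, so the data show nothing directly about this exchange. The expectation therefore starts from compound 2 at 6000 nM, with no step beyond the scatter in this assay and no favoured direction. The estimated change is small: a 1.1-fold higher number from compound 2 to compound 3 (0.03 log units; within the scatter). For compound 3 the expected value is 6500 nM, with an estimated range of 2700 nM to 15000 nM.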

Compound 3, half-maximal inhibitory concentration: 12000 nM
Compound 3: middle estimate off by 1.8-fold (0.27 log units), on the low side, and the stated range covers the measured number.
By their numbers in this assay, from the lowest: compounds 2 and 3 (each within the scatter of the next); then compound 1.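

In this assay, for the compounds shown here, the exchange of 2-fluorobenzyl for 3-chlorobenzyl gives a 2.0-fold higher number from compound 2 to compound 3 (0.30 log units; within the scatter), the first step here between compounds that differ in one place. On a saturated chain carbon bound to an aromatic nitrogen, 3-chlorophenyl can therefore stand in place of 2-fluorophenyl with no difference that can be told from the scatter, something compound 1 could not show, as it departs from compound 2 in more than one place. No measurement shown bears on why this step has the size it has.

The exchange swaps fluorine for chlorine and also changes the printed ring position of the halogen, so the compounds shown cannot separate the two, and 2-chlorobenzyl and 3-fluorobenzyl at this place would be needed to do so. Also open, going by these compounds, is how this place responds to groups of other kinds, such as an unsubstituted benzyl, a 3-aminobenzyl carrying an amine, a 3-carboxybenzyl carrying a carboxylic acid, or a longer chain such as 2-phenylethyl.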